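From methoxy to ethylamino on a carbonyl carbon

The compounds below may be only part of what the source reports. "The series", "measured", "known", "first", "only" and "open" are said of these compounds alone.

In an in vitro ADME assay on microsomes from liver (Homo sapiens) for metabolic stability (a higher number here means faster removal of the compound, a lower number slower removal), compound 1 `COC(=O)[C@H]1CC[C@@H](n2/c(=N/C(=O)c3ccccc3)[nH]c3ccc(CN4CCCCC4)cc32)CC1` gives 85 mL.min-1.g-1 as its reading. Compound 2 `CC(C)NC(=O)[C@H]1CC[C@@H](n2/c(=N/C(=O)c3cc(F)cc(Cl)c3)[nH]c3ccc(CN4CCC(C(C)(C)O)CC4)cc32)CC1` gives 83 mL.min-1.g-1 and so matches compound 1 within the scatter, while compound 3 `CC(C)NC(=O)[C@H]1CC[C@@H](n2/c(=N/C(=O)c3ccc(F)cc3)[nH]c3ccc(CN4CCCCC4)cc32)CC1` gives 302 mL.min-1.g-1 and stands beyond the scatter from both. Compound 1 therefore sits level with compound 2 and well under compound 3.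

Compound 4 `CCNC(=O)[C@H]1CC[C@@H](n2/c(=N/C(=O)c3ccccc3)[nH]c3ccc(CN4CCCCC4)cc32)CC1` is still unmeasured. It differs from compound 1 in one place: ethylamino in place of methoxy on a carbonyl carbon means ethylamino in place of methoxy on a carbonyl carbon. Among the compounds with values here, no measured pair isolates this change. Compounds 2 and 3 also carry an alkylamino group on that carbonyl carbon, but they differ from compound 1 elsewhere too, and they disagree. Compound 3 at 302 mL.min-1.g-1 suggests a rise, whereas compound 2 at 83 mL.min-1.g-1 suggests none. A moderate rise in this assay is therefore expected, though with real doubt: the estimated step is a 2.0-fold higher number from compound 1 to compound 4 (0.30 log units; within the scatter) for this change. Compound 4 is expected to read 170 mL.min-1.g-1 with an estimated range from 80 mL.min-1.g-1 to 350 mL.min-1.g-1 in this measurement.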

Compound 4, intrinsic clearance in microsomes: 194 mL.min-1.g-1
For compound 4 the middle estimate is 1.1-fold (0.06 log units) below the measured one, and the stated range covers the measured number.
By their numbers in this assay, from the lowest: compounds 2 and 1 (each within the scatter of the next); then compounds 4 and 3 (each within the scatter of the next).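

This is the only pair shown that isolates the change at this position. In this assay ethylamino in place of methoxy on a carbonyl carbon gives a 2.3-fold higher number from compound 1 to compound 4 (0.36 log units; beyond the scatter) with the rest of the structure unchanged, so this single swap, methoxycarbonyl to ethylcarbamoyl, is enough to move the reading by a modest step beyond the usual scatter. No supporting data here account for the rise, so its cause remains unknown.

The compounds shown leave open whether the rise is particular to ethylamino or would also appear with another group on the same carbonyl carbon, such as methylamino or a plain amino group. They also leave open how a carboxylic acid at this place would read against the methoxy and ethylamino groups.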